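Swapping 2-methoxyphenyl for 3-methoxyphenyl

The source may hold more compounds than are shown below. What is called first, only, known or untested is meant among the compounds shown, and "the series" means these compounds.

In an ADME assay on THP-1 cells (Homo sapiens) for cytotoxicity, read by flow cytometry and propidium iodide staining, with a stated time of 72 h (a lower number here means a stronger inhibitor, a higher number a weaker inhibitor), compound 3 `COc1ccccc1-c1oc2ccc(NC(C)=O)cc2c(=O)c1OC` gives 108000 nM and compound 1 `COc1cccc(-c2oc3ccc(NC(C)=O)cc3c(=O)c2O)c1` gives 50000 nM, a gap beyond the usual scatter that leaves compound 3 with the higher of these two numbers. Compound 2 `COc1c(-c2ccccc2)oc2ccc(NC(C)=O)cc2c1=O` reads > 125000 nM, which is a limit of the assay. Compound 4 `COc1cccc(-c2oc3ccc(NC(C)=O)cc3c(=O)c2OC)c1` is still unmeasured and has 3-methoxyphenyl in place of 2-methoxyphenyl on an aromatic carbon. For the measured compounds named here, the one measured step, an at least 1.1-fold lower number from compound 2 to compound 3 (0.06 log units; that floor lies within the scatter), also adds methoxy in place of hydrogen on an aromatic carbon, and its floor lies within the scatter. Compound 1, at 50000 nM, already carries 3-methoxyphenyl and hints at a slightly lower number. The expected change is small, within the scatter, with an estimated 1.2-fold lower number from compound 3 to compound 4 (0.08 log units; within the scatter). Compound 4 is expected at 90000 nM, with an estimated range of 50000 nM to 135000 nM.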

Compound 4, half-maximal inhibitory concentration: 5000 nM
Beside the measured number, compound 4's estimate is 18-fold (1.26 log units) above it; measured number below the stated range.
By their numbers in this assay, from the lowest: compound 4; then compound 1; then compound 3. At a limit, above all of these: compound 2.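

In this assay, for the compounds shown here, the site of a single methoxy group turns out to matter far more than the earlier compounds could show: with the same atoms joined differently, 3-methoxyphenyl in place of 2-methoxyphenyl gives a 22-fold lower number from compound 3 to compound 4 (1.33 log units; beyond the scatter). Methyl in place of hydrogen on the oxygen gives a 10-fold lower number from compound 1 to compound 4 (1.00 log units; beyond the scatter), and methoxy in place of hydrogen gives an at least 25-fold lower number from compound 2 to compound 4 (1.39 log units; beyond the scatter). The value of compound 2 is a limit: the limit of > 125000 nM in this assay, at which 1 of the 4 values shown sits.

What the compounds shown leave open is whether 4-methoxyphenyl, or an amine or carboxylic acid on that phenyl ring, would follow compound 4. They also give no reason for the gap.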